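Hydrogen in Place of Ethyl: Compound 2 to Compound 4

This account rests on a few compounds, and the source may have more. Where it says the series, first, only, none or still open, it means among the compounds named here.

Of the compounds shown here, three have so far been tested in a functional assay on the whole organism (stomach) with Rattus norvegicus as the target; a higher number here means that more compound is needed for the effect, a lower number that less compound is needed. Compound 1 `CCC/N=C(/NC#N)NCCCn1nc(-c2ccccc2)ccc1=O` gives 100 mg/kg in this assay. Compound 2 `CCC/N=C(/NC#N)NCCCCCn1nc(-c2ccccc2)ccc1=O` reaches only a limit of the assay, > 100 mg/kg, in this assay. Compound 3 `C/N=C(/NC#N)NCCCCn1nc(N(C)C)ccc1=O` likewise stops at a limit, > 100 mg/kg, in this assay. Compound 2 therefore stands at the limit of > 100 mg/kg in this assay, at which 2 of the 3 values shown sit, and no number for it is known.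

Compound 4 `C/N=C(/NC#N)NCCCCCn1nc(-c2ccccc2)ccc1=O` has not yet been measured. It differs from compound 2 by hydrogen in place of ethyl on a saturated chain carbon bound to a double-bonded nitrogen. Compound 3 carries the methyl as well, but it differs from compound 4 elsewhere, so its limit cannot be read as the effect of this change alone. Within the data shown here, with compound 2 itself resting at a limit, no measured step can be sized; the expectation is of no shift beyond the scatter, with the value again near the limit. The estimate for compound 4 is 150 mg/kg, between 60 mg/kg and 400 mg/kg. This estimate means an expected step that the limit leaves unreadable from compound 2 to compound 4.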

Compound 4, dose for half-maximal effect: 100 mg/kg
Compound 4: middle estimate off by 1.5-fold (0.18 log units), on the high side; the range from low to high includes it.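

With compound 4, this position gives its first step in this assay: hydrogen in place of ethyl on a saturated chain carbon bound to a double-bonded nitrogen gives a number no higher from compound 2 to compound 4 (the limit leaves the size open). Among these compounds, compound 4 gives a number, 100 mg/kg, so one side of this change can now be read, which no earlier compound allowed. Compound 2 remains at a limit and not a number, so the step shows only a direction: the limit of > 100 mg/kg in this assay, at which 2 of the 4 values shown sit.

The compounds shown leave open how large the step is, and whether the same change, read as propyl to methyl, would behave alike on another core. They also leave open what a longer chain such as butyl, or a hydroxyl group, would do at this place in this assay.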